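Carbamoyl replacement on going to compound 3

The compounds below may be only part of what the source reports. "The series", "measured", "known", "first", "only" and "open" are said of these compounds alone.

Measured values:
- compound 1 `C/C(=N\NC(N)=S)c1ccc2[nH]c(-c3ccc(Cl)cc3)nc2c1` gives > 100000 nM as a limit
- compound 2 `C/C(=N\NC(N)=O)c1ccc2[nH]c(C3CCCCC3)nc2c1` gives > 100000 nM as a limit

In an ADME assay on MDBK cells (Bos taurus) for cytotoxicity, read by MTT assay, with a stated time of 96 h (a higher number here means that more compound is tolerated, a lower number that less compound is tolerated), compound 2 stands at > 100000 nM, which is a limit and not a number. Among the compounds with values here, no measured step is available, and the data show only (the limit of > 100000 nM in this assay, at which 2 of the 2 values shown sit).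

Compound 3 `C/C(=N\NC(N)=S)c1ccc2[nH]c(C3CCCCC3)nc2c1` follows from compound 2 by one change on an amine nitrogen, (a group of 3 heavy atoms (1 carbon, 1 nitrogen, 1 sulfur; no ring) in place of a group of 3 heavy atoms (1 carbon, 1 nitrogen, 1 oxygen; no ring), on an amine nitrogen), with the carbamoyl leaving. Compound 1 already carries the entering group and gives > 100000 nM, also a limit. On that basis no step beyond the scatter is expected in this assay, and any step that does appear is expected towards less compound being tolerated. The estimated step is an at least 1.2-fold lower number from compound 2 to compound 3 (0.09 log units; that floor lies within the scatter). For compound 3 the expected value is 80000 nM, with an estimated range from 25000 nM to 100000 nM.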

Compound 3, half-maximal cytotoxic concentration: > 100000 nM
Compound 3: only a limit was reported; the forecaster's own chance of this, stated with the estimate: 60%; middle value at least 1.2-fold (0.09 log units) from the limit.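

In this assay compound 3 gives > 100000 nM, a limit and not a number, so its steps from compound 2 and from compound 1 cannot be read: the limit of > 100000 nM in this assay, at which 3 of the 3 values shown sit.

The compounds shown leave open whether replacing the carbamoyl, or cyclohexyl in place of 4-chlorophenyl, changes the read-out in this assay at all.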